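The source may report more compounds than this note shows. Statements on the series, on what has been measured and on what is new or still open speak of the compounds shown alone.

Compound 1 `O=C(C1=C(OC2CCCCC2)C(=O)N(CCCn2ccnc2)C1c1ccc(Br)cc1)c1ccccc1` gives 31200 nM in a functional assay on A549 cells (Homo sapiens) for antiproliferative activity, read by MTT assay, with a stated time of 72 h; a lower number here means a stronger inhibitor, a higher number a weaker inhibitor.
Compound 2 `O=C(C1=C(Nc2ccc(F)cc2)C(=O)N(CCCn2ccnc2)C1c1ccc(Br)cc1)c1ccccc1` gives 27400 nM in this assay.
Compound 3 `O=C(C1=C(Nc2ccc(I)cc2)C(=O)N(CCCn2ccnc2)C1c1ccc(Br)cc1)c1ccccc1` gives 24500 nM in this assay.

Compound 1 holds the highest of the three numbers, but its neighbours sit close: a 1.1-fold lower number from compound 1 to compound 2 (0.06 log units; within the scatter) and a 1.3-fold lower number from compound 1 to compound 3 (0.10 log units; within the scatter) both fall within the scatter, as does a 1.1-fold lower number from compound 2 to compound 3 (0.05 log units; within the scatter), so the three cannot be ranked against one another.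

Compound 4 `O=C(C1=C(Nc2cccc(Br)c2)C(=O)N(CCCn2ccnc2)C1c1ccc(Br)cc1)c1ccccc1` has not yet been measured in this assay. It departs from compound 1 as follows: (3-bromophenyl)amino in place of cyclohexyloxy on a double-bonded ring carbon.

The two steps that bear on this change are those from compound 1 to compound 2 and from compound 1 to compound 3, in which a halogenated phenylamino likewise replaced the cyclohexyloxy; both stayed within the scatter. On that basis the step to compound 4 is expected to be small, with no change beyond the scatter in either direction, a 1.2-fold lower number from compound 1 to compound 4 (0.08 log units; within the scatter). Compound 4 is therefore estimated at 26000 nM in this assay, with a range from 12000 nM to 55000 nM.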

Compound 4, half-maximal inhibitory concentration: 15800 nM
Compound 4: middle estimate off by 1.6-fold (0.22 log units), on the high side; measured number inside the range.
By their numbers in this assay, from the lowest: compounds 4, 3, 2 and 1 (each within the scatter of the next).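

For the compounds shown here, the largest step so far in this assay is a 2.0-fold lower number from compound 1 to compound 4 (0.30 log units; within the scatter) and it still does not clear the scatter. The 3-bromophenyl group, which differs from the earlier aryl groups in both its halogen and that halogen's ring position, gives a 1.6-fold lower number from compound 3 to compound 4 (0.19 log units; within the scatter) and a 1.7-fold lower number from compound 2 to compound 4 (0.24 log units; within the scatter) and so is not separated from the 4-iodophenyl or 4-fluorophenyl group. Three halogenated phenylamino groups therefore cannot be ranked at this position, and none is separated from cyclohexyloxy.

Since cyclohexyloxy and the phenylamino groups differ in both the linking atom and the ring, cyclohexylamino or phenoxy would be needed to tell these two changes apart, and a carboxylic acid on the phenyl ring remains untested among these compounds. Nothing measured here accounts for these numbers.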